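Adding an Amino Group to a Chlorinated Purine Analogue

A few compounds are considered here, and "the series" means these few. Any claim that something is new, unique, unknown or untested is made for them only; others in the source may bear on it.

Measured compounds:
Compound 1 `ClCc1ccccc1Cn1cnc2c(Cl)nc(Cl)nc21`: 6450 nM
Compound 2 `ClCc1ccccc1Cn1cnc2c(Cl)ncnc21`: 20400 nM
Compound 3 `ClCc1cccc(Cn2cnc3ncnc(Cl)c32)c1`: 60300 nM

In a functional assay on OVCAR-8 cells (Homo sapiens) for cytotoxicity, read by sulforhodamine B assay, with a stated time of 48 h (a higher number here means that more compound is tolerated, a lower number that less compound is tolerated), compound 2 gives 20400 nM, the second highest of the three numbers; compound 1 sits below it and compound 3 above it, both beyond the scatter. Compound 4 `Nc1nc(Cl)c2ncn(Cc3ccccc3CCl)c2n1` has not yet been measured. It differs from compound 2 by amino in place of hydrogen on an aromatic carbon. Going by the values given here, the only measured step that touches the same ring is a 3.2-fold higher number from compound 1 to compound 2 (0.50 log units; beyond the scatter), a modest change from swapping chloro for hydrogen. Among the compounds with values here, no measured pair introduces an amino group, so there is no direct guide. Compound 4 is therefore expected to stay close to compound 2, with a step of a 1.4-fold lower number from compound 2 to compound 4 (0.13 log units; within the scatter) in this assay. The estimate for compound 4 is 15000 nM, expected to lie between 5000 nM and 45000 nM.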

Compound 4, concentration lethal to 50% of the cells: > 100000 nM
Compound 4 gave a limit, no number; the forecaster's own chance of this, stated with the estimate: 10%; middle value at least 6.6-fold (0.82 log units) from the limit.
By their numbers in this assay, from the lowest: compound 1; then compound 2; then compound 3. At a limit, above all of these: compound 4.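

In this assay, compound 4 gives a limit rather than a number: the limit of > 100000 nM in this assay, at which 1 of the 4 values shown sits. On the carbon between two ring nitrogen atoms, amino in place of hydrogen gives an at least 4.9-fold higher number from compound 2 to compound 4 (0.69 log units; beyond the scatter). Amino in place of chloro there gives an at least 15-fold higher number from compound 1 to compound 4 (1.19 log units; beyond the scatter), so the group on this carbon can shift the number much further than the modest chloro-to-hydrogen swap had suggested.

On these data alone, the true size of both steps stays open, with only a limit for compound 4. Also open, as far as these compounds go, is whether a methylamino or hydroxyl group on this carbon would have a similar effect.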